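The compounds below may be only part of what the source reports. "The series", "measured", "known", "first", "only" and "open" are said of these compounds alone.

For the measured compounds named here, in a functional assay on MOLT-4 cells (Homo sapiens) for inhibition, read by MTT assay, with a stated time of 72 h (a lower number here means a stronger inhibitor, a higher number a weaker inhibitor), compound 1 (`COc1cc(NC(C)CCCNC(=O)NNC(=O)Nc2ccc(Br)cc2)c2ncccc2c1`) gives 209000 nM as the higher of the two numbers so far, and compound 2 (`COc1cc(NC(C)CCCNC(=O)NNC(=O)Nc2cccc(C(F)(F)F)c2)c2ncccc2c1`) gives 36000 nM as the lower. Compound 3 (`COc1cc(NC(C)CCCNC(=O)Nc2ccc(O)cc2)c2ncccc2c1`) carries 4-hydroxyphenyl in place of ((4-bromophenyl)carbamoyl)amino on an amide-type nitrogen is the full count. Going by the values given here, the only measured step is a 5.8-fold lower number from compound 1 to compound 2 (0.76 log units; beyond the scatter) and it swaps one substituted phenyl for another, so it bears only loosely on this larger change. A modest move to a lower number is expected, and the estimate is a 5.2-fold lower number from compound 1 to compound 3 (0.72 log units; beyond the scatter) in size. For compound 3 the estimated value is 40000 nM (range 10000 nM to 150000 nM).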

Compound 3, half-maximal inhibitory concentration: 21000 nM
Estimate against measurement, compound 3: 1.9-fold (0.28 log units) above; the range from low to high includes it.
By their numbers in this assay, from the lowest: compounds 3 and 2 (each within the scatter of the next); then compound 1.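

Replacing ((4-bromophenyl)carbamoyl)amino with 4-hydroxyphenyl on the amide-type nitrogen gives a 10-fold lower number from compound 1 to compound 3 (1.00 log units; beyond the scatter) in this assay, so the larger group is not needed for a lower number in this series. The change removes a whole unit rather than swapping one substituted phenyl for another, yet compound 3 lies within the scatter of compound 2. No measured evidence accounts for this step.

From the compounds shown here alone, whether the hydroxyl itself contributes remains open, since the step also changes the group's size. Going by these compounds, an amine or a carboxylic acid in place of the hydroxyl, or a longer chain to the shared core, remains untested here.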